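Pyrrolidin-1-yl in place of methoxy: an expected step

A few compounds are considered here, and "the series" means these few. Any claim that something is new, unique, unknown or untested is made for them only; others in the source may bear on it.

In a physicochemical assay for lipophilicity (on this read-out lower numbers stand for lower lipophilicity and higher numbers for higher lipophilicity), compound 1 (`Cc1cc(-c2noc([C@H](C)NC(=O)c3cc(C(F)(F)F)nn3C)n2)ccn1`) gives 3.3 and compound 2 (`COc1cc(-c2noc([C@H](C)NC(=O)c3cc(C(F)(F)F)nn3C)n2)ccn1`) gives 3.4, so compound 2 stands level with compound 1 within the scatter. Compound 3 (`C[C@H](NC(=O)c1cc(C(F)(F)F)nn1C)c1nc(-c2ccnc(N3CCCC3)c2)no1`) differs from compound 2 as follows: pyrrolidin-1-yl in place of methoxy on an aromatic carbon. Among the compounds with values here, the one measured step, a number 0.10 log units higher from compound 1 to compound 2 (within the scatter), is methoxy in place of methyl on an aromatic carbon, with no ring entering, so it gives only weak guidance on size. The entering group is the larger, so an upward step is expected, estimated as a number 0.50 log units higher from compound 2 to compound 3 (beyond the scatter). For compound 3 the estimated value is 3.9, with an expected range of 3.5 to 4.4.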

Compound 3, distribution coefficient: 4.2
Compound 3: middle estimate off by 0.30 log units, on the low side; the range from low to high includes it.
By their numbers in this assay, from the lowest: compounds 1 and 2 (each within the scatter of the next); then compound 3.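

Within the data shown here, the position next to the ring nitrogen responds to a change of group in this assay: pyrrolidin-1-yl gives a number 0.80 log units higher from compound 2 to compound 3 (beyond the scatter) and a number 0.90 log units higher from compound 1 to compound 3 (beyond the scatter) as the only steps here beyond the scatter. Among these compounds, it is also the only group here that brings a ring, with 5 heavy atoms against 2 for methoxy. Nothing on hand accounts for the size of the step.

Going by these compounds, it remains open whether the step goes with the ring or with the attached nitrogen. Dimethylamino, an open-chain amine, would separate the two, and morpholine would test a second hetero atom in the ring.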